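A few compounds are considered here, and "the series" means these few. Any claim that something is new, unique, unknown or untested is made for them only; others in the source may bear on it.

Compound 1, `CN(C)C(=O)n1cc(C(=O)c2ccn3c2CSC3c2cccnc2)c2ccc(Oc3ccc(F)cc3)cc21`: in a functional assay on the whole organism for inhibition, with Rattus norvegicus as the target (a higher number here means that more compound is needed for the effect, a lower number that less compound is needed), compound 1 gives 0.03 mg/kg.
Compound 2, `CCNC(=O)n1cc(C(=O)c2ccn3c2CSC3c2cccnc2)c2ccc(-c3ccc(F)cc3)cc21`: compound 2 gives 0.18 mg/kg.
Compound 3, `NC(=O)n1cc(C(=O)c2ccn3c2CSC3c2cccnc2)c2ccc(-c3ccc(F)cc3)cc21`: compound 3 gives 0.01 mg/kg.

Compound 3 has the lowest number of the three in this assay, with compound 1 nearest to it and compound 2 furthest away, both gaps beyond the scatter. Among the compounds with values here, the one single-point step among the measured compounds is an 18-fold lower number from compound 2 to compound 3 (1.26 log units; beyond the scatter), a large move that comes from trimming the group on the amide nitrogen down to hydrogen.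

Compound 4, `Cn1cc(C(=O)c2ccn3c2CSC3c2cccnc2)c2ccc(-c3ccc(F)cc3)cc21`, differs from compound 3 by methyl in place of carbamoyl on an aromatic nitrogen. The step from compound 2 to compound 3 bears on this only in part: there the carbamoyl stayed and only its substituent shrank, whereas here the carbamoyl itself leaves and a methyl enters. Within the data shown here, no measured pair shows the effect of removing the carbamoyl, so the direction is uncertain, and a modest rise in the number toward that of compound 1 is the more cautious expectation, a 3.0-fold higher number from compound 3 to compound 4 (0.48 log units; beyond the scatter). Compound 4 is estimated at 0.03 mg/kg, with a range from 0.008 mg/kg to 0.15 mg/kg.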

Compound 4, dose for half-maximal effect: 0.09 mg/kg
The estimate for compound 4 lay 3.0-fold (0.48 log units) below the measured number; low and high end bracket the measured number.
By their numbers in this assay, from the lowest: compound 3; then compound 1; then compounds 4 and 2 (each within the scatter of the next).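

In this assay, the aromatic nitrogen of the five-membered ring now proves sensitive to the loss of the carbamoyl itself, not only to what the carbamoyl carries: methyl in its place gives a clear change (a 9.0-fold higher number from compound 3 to compound 4 (0.95 log units; beyond the scatter)). Among these three compounds, the unsubstituted carbamoyl alone stands apart at this position, since methyl and ethylcarbamoyl cannot be told apart (a 2.0-fold lower number from compound 2 to compound 4 (0.30 log units; within the scatter)). Nothing measured here explains why the unsubstituted carbamoyl differs from both groups.

The compounds shown leave open how this nitrogen behaves with only a hydrogen on it, or with a longer chain such as propyl in place of methyl. They also leave open whether an amine or a carboxylic acid at this position would match the carbamoyl of compound 3.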